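A few compounds are considered here, and "the series" means these few. Any claim that something is new, unique, unknown or untested is made for them only; others in the source may bear on it.

Compound 1 `C=CCc1ccc(OCc2cn(-c3cccc([N+](=O)[O-])c3)nn2)c(O)c1`: 29.8%
Compound 2 `C=CCc1ccc(OCc2cn(-c3ccc(C#N)cc3)nn2)c(O)c1`: 20.8%
Compound 3 `C=CCc1ccc(OCc2cn(-c3cc(OC)c(OC)c(OC)c3)nn2)c(O)c1`: 32.8%

These values come from a functional assay on HL-60 cells (Homo sapiens) for inhibition, read by MTT assay, with a stated time of 72 h, tested at 30 uM; on this read-out higher numbers stand for more inhibition of growth at the one concentration tested and lower numbers for less inhibition of growth. Compound 2 lies within the scatter of compound 1, while compound 3 reads higher than compound 2 by more than the scatter. Compound 4 `C=CCc1ccc(OCc2cn(-c3ccccc3Cl)nn2)c(O)c1`, not yet measured, carries 2-chlorophenyl in place of 4-cyanophenyl on an aromatic nitrogen. Among the compounds with values here, no measured pair shows this change on its own, so the expectation rests only on the narrow spread of the three values. A small rise in this assay, none beyond the scatter, is expected. The estimated step of a number 5.2 percentage points higher from compound 2 to compound 4 (within the scatter) stays within the scatter. For compound 4 the expected value is 26%, with an estimated range of 14% to 39%.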

Compound 4, percent growth inhibition at one concentration: 38.7%
Estimate against measurement, compound 4: 12.7 percentage points below; the measured number falls inside the stated range.
By their numbers in this assay, from the lowest: compounds 2, 1, 3 and 4 (each within the scatter of the next, the first and the last beyond it).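

In this assay, the change on the aromatic nitrogen of the five-membered ring gives a number 17.9 percentage points higher from compound 2 to compound 4 (beyond the scatter), which shows that replacing 4-cyanophenyl with 2-chlorophenyl in one place can shift growth inhibition beyond the usual scatter. The step removes the nitrile and its hydrogen-bond acceptor and brings in a chlorine, and this single pair cannot separate those two parts of the change. Nothing available explains the rise.

As far as these compounds go, it remains open whether a methyl, an amine or a carboxylic acid in place of the chlorine would keep the higher reading. The single tested concentration also leaves open how these compounds would compare across a range of concentrations.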